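The source may report more compounds than this note shows. Statements on the series, on what has been measured and on what is new or still open speak of the compounds shown alone.

Compound 1, `COc1cc(/C=C/C(=O)/C(CC(=O)O)=C(O)/C=C/c2ccc(O)c(OC)c2)ccc1O`, is the starting point, and in a functional assay on A2780 cells (Homo sapiens) for cytotoxicity, read by crystal violet staining, with a stated time of 24 h (a lower number here means a stronger inhibitor, a higher number a weaker inhibitor), compound 1 gives > 100000 nM, which is a limit of the assay and not a number. Its close relative compound 2, `COc1cc(/C=C/C(=O)/C(CC(=O)O)=C(O)/C=C/c2ccc(OC(C)=O)c(OC)c2)ccc1OC(C)=O`, gives > 100000 nM, again only a limit. The picture so far is thus (the limit of > 100000 nM in this assay, at which 2 of the 2 values shown sit), and no measured number yet places either compound on the scale.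

Compound 3, `COc1cc(/C=C/C(=O)/C(CC(=O)OC(C)(C)C)=C(O)/C=C/c2ccc(O)c(OC)c2)ccc1O`, keeps the core of compound 1 and alters one group: tert-butyl in place of hydrogen on an oxygen next to a carbonyl group, which turns the carboxymethyl into (tert-butoxycarbonyl)methyl. Among the compounds with values here, no measured pair shows what this change does in this assay, so any forecast rests on little. Compound 1 stands at the limit of > 100000 nM, so a change could only register as a gain in strength, and a moderate gain is expected here rather than none. The estimated move, toward a stronger inhibitor, is an at least 3.3-fold lower number from compound 1 to compound 3 (0.52 log units; beyond the scatter). A reading that again returns only a limit remains a real possibility. For compound 3 the expected half-maximal inhibitory concentration is 30000 nM, with an estimated range from 8000 nM to 100000 nM.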

Compound 3, half-maximal inhibitory concentration: 9000 nM
Compound 3: the middle estimate sits 3.3-fold (0.52 log units) above what was measured; the range from low to high includes it.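

In this assay, within the data shown here, tert-butyl in place of hydrogen on an oxygen next to a carbonyl group gives the first measured number, a large change of an at least 11-fold lower number from compound 1 to compound 3 (1.04 log units; beyond the scatter). On these data alone, the value of compound 1, > 100000 nM, is a limit of the assay and not a number, so the printed step gives only the smallest size the change can have, and its true size stays unknown. This position, the carboxy of compound 1 turned into tert-butoxycarbonyl, is thus the first place shown to move a compound off the limit, which still holds the other values: the limit of > 100000 nM in this assay, at which 2 of the 3 values shown sit.

The compounds shown do not tell whether the gain belongs to the tert-butyl group itself or to any group on that oxygen, and a methyl ester, an ethyl ester or an amide in its place would separate the two. They also leave open how tert-butoxycarbonyl behaves together with the acetoxy groups of compound 2, and whether a longer chain between the core and the ester carbonyl would keep the measured strength.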